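Chain length and disulfide half-life: compound 3 to compound 4

The source may report more compounds than this note shows. Statements on the series, on what has been measured and on what is new or still open speak of the compounds shown alone.

Compound 1, `C=CCSS[C@H]1C[C@H](n2cc(C)c(=O)[nH]c2=O)O[C@@H]1CO`: < 8 h
Compound 2, `CCCCSS[C@H]1C[C@H](n2cc(C)c(=O)[nH]c2=O)O[C@@H]1CO`: < 8 h
Compound 3, `CCCCCCSS[C@H]1C[C@H](n2cc(C)c(=O)[nH]c2=O)O[C@@H]1CO`: < 8 h

Three disulfide-linked nucleosides share one core and differ only in the chain on the outer sulfur. In a physicochemical assay for metabolic stability, in the presence of a further agent that is not named here (on this read-out higher numbers stand for a longer-lived compound and lower numbers for a shorter-lived compound), compound 1 gives < 8 h, which is a limit of the assay and not a number. Compound 2 likewise gives < 8 h in this assay, again a limit. Compound 3 gives < 8 h in this assay, also a limit. Thus (the limit of < 8 h in this assay, at which 3 of the 3 values shown sit), and the steps a step that the two limits leave unreadable from compound 1 to compound 2, a step that the two limits leave unreadable from compound 1 to compound 3 and a step that the two limits leave unreadable from compound 2 to compound 3 are all unreadable, because each pair sits at the same limit.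

Compound 4, `CCCCCCCCSS[C@H]1C[C@H](n2cc(C)c(=O)[nH]c2=O)O[C@@H]1CO`, differs from compound 3 by ethyl in place of hydrogen on a saturated chain carbon, six bonds along the chain from a sulfur. Because the limit of < 8 h in this assay, at which 3 of the 3 values shown sit, covers the whole chain-length series shown, no readable step bears on this change, and compound 4 is expected to behave like compound 3: the step that the limit leaves unreadable from compound 3 to compound 4 is expected to stay within the scatter. Compound 4 is therefore estimated at 4 h in this assay, in the range 1 h to 10 h, most likely reported again only as a limit.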

Compound 4, half-life: < 8 h
Compound 4 was reported as a limit; the forecaster's own chance of this, stated with the estimate: 80%; the middle value is on the limit's open side.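

In this assay compound 4 gives < 8 h as a limit and not a number. Its steps from compound 1, compound 2 and compound 3 cannot be read, because all four sit at one limit: (the limit of < 8 h in this assay, at which 4 of the 4 values shown sit). The compounds shown leave open how long any of these disulfides actually lasts and whether chain length alters that.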